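The source may hold more compounds than are shown below. What is called first, only, known or untested is meant among the compounds shown, and "the series" means these compounds.

Working notes on the series. Three compounds have results so far in an assay on isolated protein for inhibition of long-chain fatty acid transport protein 1 (Mus musculus), read by scintillation counting, with a stated time of 20 min; on this read-out lower numbers stand for stronger inhibition and higher numbers for weaker inhibition. Compound 1 `O=C(CN1CCN(c2ccc(F)cc2)CC1)Nc1nc2ccccc2s1` gives only a limit, > 10000 nM, in this assay. Compound 2 `O=C(CN1CCN(c2ccc(F)cn2)CC1)Nc1nc2c(s1)CCCC2` gives 600 nM in this assay. Compound 3 `O=C(CN1CCN(c2ccc(F)cc2)CC1)Nc1nc2c(s1)CCCCC2` gives 2000 nM in this assay. Compound 2 thus holds the lower of the two numbers actually reported; the nearest, compound 3, sits higher by a gap beyond the usual scatter, and the third entry is a limit. Compound 1 sits at the limit noted as the limit of > 10000 nM in this assay, at which 1 of the 3 values shown sits. No pair among these three differs in a single place, so no measured step is available: compound 1 and compound 3 share the group on the amine nitrogen but differ in their cores, as do compound 2 and compound 3.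

Compound 4 `O=C(CN1CCN(c2ccc(F)cc2)CC1)Nc1nc2c(s1)CCCC2` is not yet measured. It differs from compound 2 in one place: 4-fluorophenyl in place of 5-fluoropyridin-2-yl on an amine nitrogen in a ring. Nothing measured isolates this exchange. For the measured compounds named here, compound 2 is the only compound carrying the 5-fluoropyridin-2-yl group and also the only one with its core, so the two features cannot be separated. Compound 3, which also carries 4-fluorophenyl and has a number, gives 2000 nM, higher than compound 2, which leans toward a loss on exchange. Compound 4 is therefore expected at 1500 nM, within 400 nM to 6000 nM. The step of a 2.5-fold higher number from compound 2 to compound 4 (0.40 log units; beyond the scatter) is an expected loss of moderate size, near the edge of the scatter.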

Compound 4, half-maximal inhibitory concentration: 4000 nM
Compound 4: middle estimate off by 2.7-fold (0.43 log units), on the low side; measured number inside the range.
By their numbers in this assay, from the lowest: compound 2; then compounds 3 and 4 (each within the scatter of the next). At a limit, above all of these: compound 1.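

In this assay, for the compounds shown here, the exchange of 5-fluoropyridin-2-yl for 4-fluorophenyl on an amine nitrogen in a ring gives the first measured step: a 6.7-fold higher number from compound 2 to compound 4 (0.82 log units; beyond the scatter). With the core held constant, this step separates the group from the core, which compound 2 alone could not do, and shows that on this core the change from 5-fluoropyridin-2-yl to 4-fluorophenyl alone carries a loss beyond the scatter. The two groups differ in the count of one ring nitrogen and one hydrogen-bond acceptor, but nothing at hand gives a measured property that accounts for the size of this step.

Open, on these data alone, is whether the same exchange gives a step of similar direction and size on the cores of compound 1 and compound 3, as the present step rests on a single pair and a single core. Also open, as far as these compounds go, is how other groups at this place, such as pyrimidin-2-yl or a pyridin-2-yl ring carrying chlorine in place of fluorine, would read against 5-fluoropyridin-2-yl.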